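The compounds below may be only part of what the source reports. "The series", "measured", "known", "first", "only" and "open" are said of these compounds alone.

Two compounds share one core. Compound 1 `O=c1cc(Cn2cc(CCO)nn2)c2ccc(O)cc2o1` and compound 2 `O=c1cc(Cn2cc(CCCO)nn2)c2ccc(O)cc2o1` differ only in that compound 2 carries hydroxymethyl in place of hydroxy on a saturated chain carbon, two bonds along the chain from an aromatic carbon. In a functional assay on A549 cells (Homo sapiens) for inhibition, read by MTT assay, with a stated time of 72 h (on this read-out lower numbers stand for stronger inhibition and higher numbers for weaker inhibition), compound 1 gives 90300 nM, and compound 2 gives 96200 nM; the step between them is a 1.1-fold higher number from compound 1 to compound 2 (0.03 log units; within the scatter). Among the compounds with values here, compound 2 thus holds the higher of the two numbers, yet its only neighbour is compound 1, and the two lie within the scatter of each other. Compound 3 `O=c1cc(Cn2cc(-c3cc(F)cc(F)c3)nn2)c2ccc(O)cc2o1` is the next step: 3,5-difluorophenyl in place of 3-hydroxypropyl on an aromatic carbon. Within the data shown here, no measured step resembles this change; the single known step, a 1.1-fold higher number from compound 1 to compound 2 (0.03 log units; within the scatter), stayed within the scatter and gives no direction. The expected step is a 1.4-fold lower number from compound 2 to compound 3 (0.14 log units; within the scatter), with wide bounds. Compound 3 is estimated at 70000 nM, in the range 15000 nM to 250000 nM.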

Compound 3, half-maximal inhibitory concentration: 21100 nM
The estimate for compound 3 lay 3.3-fold (0.52 log units) above the measured number; the range from low to high includes it.
By their numbers in this assay, from the lowest: compound 3; then compounds 1 and 2 (each within the scatter of the next).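

In this assay, the group on this aromatic carbon of the five-membered ring does matter: putting 3,5-difluorophenyl in place of 3-hydroxypropyl gives a 4.6-fold lower number from compound 2 to compound 3 (0.66 log units; beyond the scatter), and putting it in place of 2-hydroxyethyl gives a 4.3-fold lower number from compound 1 to compound 3 (0.63 log units; beyond the scatter). Changing the chain's length had stayed within the scatter, so only the swap from chain to ring moves the number beyond it, and that swap changes several things at once: the ring, the fluorines and the loss of the hydroxy group. No independent measurement here explains the lower number.

Still open, as far as these compounds go, is whether the ring itself or its fluorines carry this step, which a plain phenyl would help to separate. An amine or a carboxylic acid at the end of the chain would show whether the chain can be improved without any ring.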